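The source may hold more compounds than are shown below. What is called first, only, known or untested is meant among the compounds shown, and "the series" means these compounds.

Measured compounds:
compound 1 `CCOc1cc(CCc2nc(C)c(CC)s2)nc(NCc2cc(Cl)cc(NC(=O)OC(C)C)c2)c1` — 33 nM
compound 2 `CCc1sc(CCc2cc(OC3CCC3)cc(NCc3cc(Cl)cc(NC(=O)OC(C)C)c3)n2)nc1C` — 11 nM

In an assay on cells for binding affinity to Neuropeptide Y receptor type 1 (Homo sapiens) (on this read-out higher numbers stand for weaker inhibition and lower numbers for stronger inhibition), compound 1 gives 33 nM and compound 2 gives 11 nM. Among the compounds with values here, the single measured step reads a 3.0-fold lower number from compound 1 to compound 2 (0.48 log units; beyond the scatter), so compound 2 holds the lower of the two numbers, beyond the scatter of the only neighbour it has.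

Compound 3 `CCc1sc(CCc2cc(OC3CCOCC3)cc(NCc3cc(Cl)cc(NC(=O)OC(C)C)c3)n2)nc1C` has not been measured. Relative to compound 2 the change is oxan-4-yl in place of cyclobutyl on an oxygen on an aromatic ring; cut one bond further out, the same difference reads cyclobutyloxy to (oxan-4-yl)oxy. Within the data shown here, the only step that touches the same place is a 3.0-fold lower number from compound 1 to compound 2 (0.48 log units; beyond the scatter), which went from ethyl to cyclobutyl, a modest gain. Among the measured compounds shown here, no measured step exchanges a ring of carbon only for a ring with one hetero atom at this position, so the direction of the new step is not anchored by data. The working expectation is a change within the scatter, with a wide range on either side.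

Compound 3 is expected to give about 13 nM in this assay, between 4 nM and 45 nM. The estimate corresponds to an expected step of a 1.2-fold higher number from compound 2 to compound 3 (0.07 log units; within the scatter).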

Compound 3, half-maximal inhibitory concentration: 4.4 nM
Compound 3: the middle estimate sits 3.0-fold (0.47 log units) above what was measured, and the stated range covers the measured number.
By their numbers in this assay, from the lowest: compound 3; then compound 2; then compound 1.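

In this assay, the place on an oxygen on an aromatic ring still has room to move after cyclobutyl: oxan-4-yl in its place gives a 2.5-fold lower number from compound 2 to compound 3 (0.40 log units; beyond the scatter) and so extends the trend rather than reversing it. Measured against ethyl, the same group gives a 7.5-fold lower number from compound 1 to compound 3 (0.88 log units; beyond the scatter) in the same direction, so the three compounds now run in one order at this single place, from ethyl through cyclobutyl to oxan-4-yl, and a six-membered non-aromatic ring with a hydrogen-bond acceptor is accepted here without loss. Ring size and the ring oxygen change together in this step, and nothing at hand separates their shares in the gain.

Cyclohexyl, the all-carbon ring of the same size, and oxetan-3-yl, a smaller ring that keeps the oxygen, would pull those two changes apart. Also open, going by these compounds, is how the number responds at this place to a ring amine such as piperidin-4-yl or to a longer open chain such as 2-methoxyethyl.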